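Isobutyl in place of hydrogen on the cyanoguanidine amine

The source may hold more compounds than are shown below. What is called first, only, known or untested is meant among the compounds shown, and "the series" means these compounds.

Compound 2 `N#C/N=C(\N)NCCCCc1c[nH]cn1` is measured in an in vitro functional assay on Sf9 cells for antagonist activity at histamine H2 receptor (Homo sapiens) (on this read-out lower numbers stand for lower potency and higher numbers for higher potency (the scale is a negative logarithm)), only as a limit: compound 2 gives < 5, a limit of the assay rather than a number. Compound 2 thus sits at the limit of < 5 in this assay, at which 1 of the 2 values shown sits. In this assay compound 1 `N#C/N=C(/NCCCCc1c[nH]cn1)NCCCc1ccncc1` gives 5.11. Compound 3 `CC(C)CN/C(=N\C#N)NCCCCc1c[nH]cn1` differs from compound 2 by isobutyl in place of hydrogen on an amine nitrogen. For the measured compounds named here, no measured step connects the two, so the expected step from compound 2 to compound 3 in this assay, a number at least 0.20 log units higher from compound 2 to compound 3 (that floor lies within the scatter), is upward but modest and uncertain. Compound 3 is expected to give 5.2, within a range from 4.6 to 5.8.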

Compound 3, negative logarithm of the antagonist equilibrium constant: < 5
Compound 3: only a limit was reported; the forecaster's own chance of this, stated with the estimate: 35%; middle value at least 0.20 log units away from the limit.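

In this assay compound 3 gives < 5, a limit of the assay and not a number. The step from hydrogen to isobutyl on this amine nitrogen cannot be read, and isobutyl leaves the series at the limit: the limit of < 5 in this assay, at which 2 of the 3 values shown sit. Isopropyl in place of 2-(pyridin-4-yl)ethyl gives a number at least 0.11 log units lower from compound 1 to compound 3 (that floor lies within the scatter), so this change cannot be told apart from the scatter. Where compound 2 and compound 3 truly lie under the limit stays open. So does whether a benzyl group or a longer chain on this amine nitrogen would give a readable number.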